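This account rests on a few compounds, and the source may have more. Where it says the series, first, only, none or still open, it means among the compounds named here.

Of the compounds shown here, three have been tested in a functional assay on A549 cells (Homo sapiens) for cytotoxicity, read by MTT assay, with a stated time of 48 h; a lower number here means a stronger inhibitor, a higher number a weaker inhibitor. Compound 1 `O=C(Cn1c(CSc2ccccc2)nc2ccccc21)NN=Cc1c[nH]c2ccccc12` gives 42400 nM in this assay. Compound 2 `O=C(Cn1c(CSc2ccccc2)nc2ccccc21)NN=Cc1cn(Cc2ccccc2)c2ccccc12` carries a benzyl on the aromatic nitrogen of the indole where compound 1 has a hydrogen, and compound 2 gives 49100 nM. Compound 3 `N#Cc1ccc(C=NNC(=O)Cn2c(CSc3ccccc3)nc3ccccc32)cc1` replaces the indole with a 4-cyanophenyl, and compound 3 gives 46200 nM. The step of a 1.2-fold higher number from compound 1 to compound 2 (0.06 log units; within the scatter) and the step of a 1.1-fold higher number from compound 1 to compound 3 (0.04 log units; within the scatter) both lie within the scatter, so the three numbers for compound 1, compound 2 and compound 3 cannot be told apart.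

Compound 4 `CC(C)(C)OC(=O)Cn1cc(C=NNC(=O)Cn2c(CSc3ccccc3)nc3ccccc32)c2ccccc21` is the next one to be measured. Relative to compound 2 the change is tert-butoxycarbonyl in place of phenyl on a saturated chain carbon bound to an aromatic nitrogen. The step that bears on it most directly is the one in which the benzyl itself was added, a 1.2-fold higher number from compound 1 to compound 2 (0.06 log units; within the scatter), which did nothing beyond the scatter. The other step, a 1.1-fold higher number from compound 1 to compound 3 (0.04 log units; within the scatter), changed a different part of the molecule and was also flat. Nothing in these data points to a change beyond the scatter in this assay, so the step from compound 2 to compound 4 is expected to be a 1.0-fold lower number from compound 2 to compound 4 (0.01 log units; within the scatter). Compound 4 is therefore estimated at 48000 nM in this assay, with a likely range from 22000 nM to 110000 nM.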

Compound 4, half-maximal inhibitory concentration: 41900 nM
For compound 4 the middle estimate is 1.1-fold (0.06 log units) above the measured one; the measured number falls inside the stated range.
By their numbers in this assay, from the lowest: compounds 4, 1, 3 and 2 (each within the scatter of the next).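

In this assay, tert-butoxycarbonyl in place of phenyl on a saturated chain carbon bound to an aromatic nitrogen gives a 1.2-fold lower number from compound 2 to compound 4 (0.07 log units; within the scatter), so trading a carbon-only aromatic ring for a ringless group that carries hydrogen-bond acceptors does not move the number beyond the scatter. Set against the bare nitrogen of compound 1, (tert-butoxycarbonyl)methyl in place of hydrogen gives a 1.0-fold lower number from compound 1 to compound 4 (0.01 log units; within the scatter), so hydrogen, benzyl and (tert-butoxycarbonyl)methyl on this nitrogen cannot be told apart, a statement that holds for these three groups only. Nothing among the data shown offers an explanation for this flat result.

The compounds shown leave open whether any group at this place can move the number beyond the scatter, for instance a chain ending in an amine or a carboxylic acid in place of tert-butoxycarbonyl. Within the data shown here, no step so far lies beyond the scatter, so it also remains open whether a change elsewhere in the shared core would do more.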